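This account rests on a few compounds, and the source may have more. Where it says the series, first, only, none or still open, it means among the compounds named here.

Series notes. The shared core of compound 1 `COc1ccc(C(=O)c2sc(Nc3ccccc3)nc2N)cc1OC` is carried into compound 2 `COc1ccc(Nc2nc(N)c(C(=O)c3ccc(OC)c(OC)c3)s2)cc1` and compound 3 `COc1ccc(C(=O)c2sc(Nc3ccc(Cl)cc3)nc2N)cc1`; the unmeasured member is compound 4 `Nc1nc(Nc2ccc(Cl)cc2)sc1C(=O)c1ccccc1`. In a functional assay on L1210 cells (Mus musculus) for antiproliferative activity, read by cell counting, with a stated time of 2 days (a lower number here means a stronger inhibitor, a higher number a weaker inhibitor), compound 2 gives 38 nM. For compound 1 this assay returns only a limit, > 10000 nM. For compound 3 the same assay again returns only a limit, > 10000 nM. Two of the three measured values therefore sit at the limit of > 10000 nM in this assay, at which 2 of the 3 values shown sit.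

Among the measured compounds shown here, the one counted step is the change from compound 2 to compound 1, (hydrogen in place of methoxy on an aromatic carbon), and it is large: an at least 260-fold higher number from compound 2 to compound 1 (2.42 log units; beyond the scatter). The difference between the cores of compound 2 and compound 3 is not broken down here.

Compound 4 arises from compound 3 by the same kind of change, (hydrogen in place of methoxy on an aromatic carbon). The place lines read alike, yet the wider cut differs: from compound 2 to compound 1 it reads 4-methoxyphenyl to phenyl and also (4-methoxyphenyl)amino to anilino, whereas from compound 3 to compound 4 it reads only 4-methoxyphenyl to phenyl, so the methoxy leaves a different ring of the molecule. For the measured compounds named here, no measured pair shows what loss of methoxy from that ring does.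

Expectation: compound 3 already stands at a limit, and the only measured removal of a methoxy, an at least 260-fold higher number from compound 2 to compound 1 (2.42 log units; beyond the scatter), weakened potency sharply, so compound 4 is expected to remain at or beyond the limit, with a step that the limit leaves unreadable from compound 3 to compound 4 in this assay. The estimate for compound 4 in this assay is 30000 nM, within 10000 nM to 100000 nM, most likely reported again as a limit rather than a number.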

Compound 4, half-maximal inhibitory concentration: > 10000 nM
Compound 4: a limit, no number; the forecaster's own chance of this, stated with the estimate: 85%; the middle value does not contradict the limit.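

In this assay compound 4 returns only a limit, > 10000 nM. No step can be read from compound 3 to compound 4, as both rest on limits: the limit of > 10000 nM in this assay, at which 3 of the 4 values shown sit.

The compounds shown leave open what the change from 4-methoxyphenyl to phenyl does at this place in the molecule: no pair with a number on both sides carries it.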